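Tetrahydroisoquinoline sulfonamide in place of the methylsulfonamide

The source may report more compounds than this note shows. Statements on the series, on what has been measured and on what is new or still open speak of the compounds shown alone.

Compound 1 `CNS(=O)(=O)c1ccc(NC(=O)NCc2ccncc2)cc1` is the reference point of this small set. In an assay on isolated protein for activation of Nicotinamide phosphoribosyltransferase (Homo sapiens) (a higher number here means that more compound is needed for the effect, a lower number that less compound is needed), compound 1 gives 3230 nM, the lowest of the two numbers recorded. Compound 2 `CCOC(=O)c1ccc(N/C(=N\C#N)NCc2ccncc2)cc1` replaces the urea with a cyanoguanidine and carries an ethyl ester in place of the sulfonamide; in this assay compound 2 gives 41400 nM, a gap from compound 1 that is well beyond the scatter. Compound 3 `CCOC(=O)c1ccc(NC(=O)N(C)Cc2ccncc2)cc1` keeps the ethyl ester and adds a methyl to the urea. For compound 3 this assay reports only a limit, > 100000 nM; the set thus holds one entry that sits at the limit of > 100000 nM in this assay, at which 1 of the 3 values shown sits, rather than at a number.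

Compound 4 `O=C(NCc1ccncc1)Nc1ccc(S(=O)(=O)N2CCc3ccccc3C2)cc1` is not yet measured. It is built from compound 1 by one change at the sulfonyl sulfur: 1,2,3,4-tetrahydroisoquinolin-2-yl in place of methylamino on a sulfonyl sulfur. Among the measured compounds shown here, no measured pair in the set reports a comparable step, so the expectation rests on the place of compound 1 alone. The step is expected to run toward a lower number, of moderate size, a 3.2-fold lower number from compound 1 to compound 4 (0.51 log units; beyond the scatter). Compound 4 is estimated to give about 1000 nM in this assay, with a likely range from 200 nM to 5000 nM.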

Compound 4, half-maximal effective concentration: 142 nM
Compound 4: middle estimate off by 7.0-fold (0.85 log units), on the high side; measured number below the stated range.
By their numbers in this assay, from the lowest: compound 4; then compound 1; then compound 2. At a limit, above all of these: compound 3.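

In this assay the sulfonyl sulfur proves to be a place that accepts a much larger group than methylamino, and the number falls sharply: 1,2,3,4-tetrahydroisoquinolin-2-yl in place of methylamino gives a 23-fold lower number from compound 1 to compound 4 (1.36 log units; beyond the scatter). Among the compounds shown here, the earlier compounds offered no step at this place, so this is the first direct reading of the group on the sulfonyl sulfur, and it also shows that the hydrogen-bond donor counted on methylamino is not needed for a number of this order, as the entering group has none. No measured property of these compounds bears on this step, and the single pair gives no account of it.

This one step does not separate the contribution of the non-aromatic ring from that of the aromatic ring in the entering group, nor the loss of the donor from the gain in size. From the compounds shown here alone, a piperidine or a dimethylamino group on the same sulfonyl sulfur would bear on both questions, and how far substituents on the aromatic ring of the entering group shift the number also remains open.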